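Anilino for hydroxy: from compound 1 to compound 3

A few compounds are considered here, and "the series" means these few. Any claim that something is new, unique, unknown or untested is made for them only; others in the source may bear on it.

Going by the values given here, compound 1 `CN1CC[C@H](c2ccc(Cl)cc2)[C@@H](CCC(=O)O)C1` gives 1300 nM in an assay on striatum with sodium-dependent dopamine transporter (Rattus norvegicus) as the target (on this read-out higher numbers stand for weaker inhibition and lower numbers for stronger inhibition), the highest of the two numbers measured so far. Its nearest measured neighbour, compound 2 `COC(=O)/C=C/[C@H]1CN(C)CC[C@@H]1c1ccc(Cl)cc1`, gives 53 nM in this assay; the step of a 25-fold lower number from compound 1 to compound 2 (1.39 log units; beyond the scatter) goes with 2-(methoxycarbonyl)ethenyl in place of 2-carboxyethyl on a saturated ring carbon. Compound 3 `CN1CC[C@H](c2ccc(Cl)cc2)[C@@H](CCC(=O)Nc2ccccc2)C1` differs from compound 1 by anilino in place of hydroxy on a carbonyl carbon. Among the compounds with values here, only the step from compound 1 to compound 2 bears on this change, and only in part: it too removes the hydroxy from the carbonyl carbon, but it alters the chain at the same time, so it gives a rough ceiling rather than a direct precedent. A lower number than for compound 1 is expected for compound 3, with a step of an 8.7-fold lower number from compound 1 to compound 3 (0.94 log units; beyond the scatter) that should lie beyond the scatter. For compound 3 the estimated value in this assay is 150 nM, with a range from 30 nM to 700 nM.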

Compound 3, inhibition constant: 201 nM
For compound 3 the middle estimate is 1.3-fold (0.13 log units) below the measured one; the range from low to high includes it.
By their numbers in this assay, from the lowest: compound 2; then compound 3; then compound 1.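

In this assay, replacing hydroxy with anilino on the carbonyl carbon gives a 6.5-fold lower number from compound 1 to compound 3 (0.81 log units; beyond the scatter) with the saturated chain left intact. The earlier step, a 25-fold lower number from compound 1 to compound 2 (1.39 log units; beyond the scatter), changed the end group and the chain together, whereas this one shows that a change at the carbonyl carbon alone is enough to lower the number beyond the scatter. Nothing measured here accounts for the size of this step.

On these data alone, it remains open whether the aromatic ring of anilino is needed, which a small amine such as methylamino on the same carbonyl carbon would test. Also open, as far as these compounds go, are how much of the earlier step a methoxy on the saturated chain would reproduce, and how a longer chain carrying anilino would read.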